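Isopropoxy to hydroxy: expected cytotoxicity of compound 4

A few compounds are considered here, and "the series" means these few. Any claim that something is new, unique, unknown or untested is made for them only; others in the source may bear on it.

Values in an ADME assay on L132 cells (Homo sapiens) for cytotoxicity, read by MTT assay, with a stated time of 72 h; a higher number here means a weaker inhibitor, a lower number a stronger inhibitor:
- compound 1 `COc1ccc(C2=C(c3cc(OC)c(OC)c(OC)c3)C(=O)C(OC(C)=O)C2)cc1OC(C)C`: > 100 ug/mL
- compound 2 `COc1cc(C2=C(c3cc(C)c(OC)c(C)c3)C(OC(C)=O)CC2=O)cc(OC)c1OC`: > 100 ug/mL
- compound 3 `COc1ccc(C2=C(c3cc(OC)c(OC)c(OC)c3)C(=O)C(O[SiH2]C(C)(C)C)C2)cc1OC(C)C`: 7 ug/mL
- compound 4 `COc1ccc(C2=C(c3cc(OC)c(OC)c(OC)c3)C(=O)C(OC(C)=O)C2)cc1O`: not yet measured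

Compound 1 gives only a limit, and it stands at the limit of > 100 ug/mL in this assay, at which 2 of the 3 values shown sit. Compound 4 differs by hydrogen in place of isopropyl on an oxygen on an aromatic ring, with hydrogen in place of isopropyl on an oxygen on an aromatic ring. For the measured compounds named here, no measured step covers this change. Going by the values given here, the one measured step, an at least 14-fold lower number from compound 1 to compound 3 (1.15 log units; beyond the scatter), is large, but it lies on an oxygen on a saturated carbon, so it bears only indirectly by showing that one change can take compound 1 off its limit. Though not firmly, a moderate fall is therefore expected as an at least 1.6-fold lower number from compound 1 to compound 4 (0.22 log units; that floor lies within the scatter). A reading at the limit remains quite possible. The estimated value for compound 4 is 60 ug/mL, with an expected range of 8 ug/mL to 150 ug/mL.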

Compound 4, half-maximal inhibitory concentration: 6 ug/mL
The estimate for compound 4 lay 10-fold (1.00 log units) above the measured number, and the stated range ends above it.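

In this assay, hydrogen in place of isopropyl on an oxygen on an aromatic ring gives an at least 16-fold lower number from compound 1 to compound 4 (1.22 log units; beyond the scatter). This place, and not only the oxygen on a saturated carbon, can therefore carry a large step. Its true size stays open, since the step starts from a limit: the limit of > 100 ug/mL in this assay, at which 2 of the 4 values shown sit.

Open, as far as these compounds go, is how methoxy or an amine would read in this place. Also open, from the compounds shown here alone, is how hydroxy here would combine with the change on the saturated carbon that leads to compound 3.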